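Chloro in place of hydrogen on compound 2

The source may report more compounds than this note shows. Statements on the series, on what has been measured and on what is new or still open speak of the compounds shown alone.

compound 1 `COc1cc(-c2nn(-c3cccc(NC(=O)c4cccc(C(F)(F)F)c4)c3)cc2-c2ccncc2)ccc1Cl` at > 50000 nM (a limit)
compound 2 `COc1cc(-c2nn(-c3cccc(NC(=O)Nc4cccc(C(F)(F)F)c4)c3)cc2-c2ccncc2)ccc1Cl` at 1870 nM (a number)

Both readings come from a functional assay on M14 cells (Homo sapiens) for inhibition, read by sulforhodamine B assay, with a stated time of 48 h (on this read-out lower numbers stand for stronger inhibition of growth and higher numbers for weaker inhibition of growth), and only compound 2 has a number there. The reading of compound 1 is a limit and not a number. Compound 3 `COc1cc(-c2nn(-c3cccc(NC(=O)Nc4ccc(Cl)c(C(F)(F)F)c4)c3)cc2-c2ccncc2)ccc1Cl` is compound 2 with one change, chloro in place of hydrogen on an aromatic carbon in all: chloro in place of hydrogen on an aromatic carbon, ortho to a trifluoromethyl group. Among the measured compounds shown here, the single measured step is an at least 26-fold lower number from compound 1 to compound 2 (1.42 log units; beyond the scatter) and it is large, yet it sits at the carbonyl and not on this aromatic ring, so it sets no size for chloro. From compound 2 at 1870 nM only a small shift towards a lower number in this assay is expected, probably inside the scatter. The expected step is a 1.6-fold lower number from compound 2 to compound 3 (0.19 log units; within the scatter) on this estimate. For compound 3 the estimated value is 1200 nM with an expected range from 400 nM to 4000 nM for now.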

Compound 3, concentration for total growth inhibition: 3710 nM
Beside the measured number, compound 3's estimate is 3.1-fold (0.49 log units) below it; measured number inside the range.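

In this assay, chloro in place of hydrogen on the aromatic carbon ortho to a trifluoromethyl group gives a 2.0-fold higher number from compound 2 to compound 3 (0.30 log units; within the scatter), so on these data this position accepts chloro with no change that can be told from the scatter. The large difference at the carbonyl carbon also holds with chloro present, with (4-chloro-3-(trifluoromethyl)phenyl)amino in place of 3-(trifluoromethyl)phenyl: an at least 13-fold lower number from compound 1 to compound 3 (1.12 log units; beyond the scatter). Compound 1 reads as a limit, so this step is a bound and not a measured size: the limit of > 50000 nM in this assay, at which 1 of the 3 values shown sits.

On these data alone, whether another group on the same carbon, such as methoxy, an amine or a carboxylic acid, would move the number beyond the scatter stays open. Also open, as far as these compounds go, is how chloro at this position would read on the 3-(trifluoromethyl)phenyl group attached directly to the carbonyl carbon.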